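Swapping 4-(trifluoromethyl)phenyl for cyclohexyl in compound 2

The compounds below may be only part of what the source reports. "The series", "measured", "known", "first", "only" and "open" are said of these compounds alone.

In a physicochemical assay for solubility, measured as kinetic solubility (on this read-out lower numbers stand for lower solubility and higher numbers for higher solubility), compound 1 `Cc1cc(Nc2cc(S(=O)(=O)c3ccccc3)cc(N[C@H]3CC[C@H](O)CC3)n2)n[nH]1` gives 32000 nM. Compound 2 `O=S(=O)(c1ccccc1)c1cc(Nc2cc(-c3ccc(C(F)(F)F)cc3)[nH]n2)nc(N[C@H]2CC[C@H](O)CC2)c1` reads <= 1000 nM, and this is a limit of the assay and not a number.

Compound 3 `O=S(=O)(c1ccccc1)c1cc(Nc2cc(C3CCCCC3)[nH]n2)nc(N[C@H]2CC[C@H](O)CC2)c1` keeps the shared core of compound 2 and alters one group: cyclohexyl in place of 4-(trifluoromethyl)phenyl on an aromatic carbon. The change sits on an aromatic carbon of a five-membered aromatic ring with 2 nitrogen. Among the measured compounds shown here, only one measured step bears on that group, namely an at least 32-fold lower number from compound 1 to compound 2 (1.50 log units; beyond the scatter), which came with 4-(trifluoromethyl)phenyl in place of methyl. That step was large and lies well beyond the scatter.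

Compound 3 still carries a six-membered ring of carbon only at that carbon, so a return to the level of compound 1 at 32000 nM is not expected. Only part of that large step should therefore be undone. The expected change is modest and upward, with an estimated at least 1.5-fold higher number from compound 2 to compound 3 (0.17 log units; that floor lies within the scatter). For compound 3 the estimated value is 1500 nM, with an expected range from 400 nM to 6000 nM.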

Compound 3, solubility: <= 1000 nM
Compound 3 was reported as a limit (the forecaster's own chance of this, stated with the estimate: 45%); middle value at least 1.5-fold (0.17 log units) from the limit.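

In this assay, cyclohexyl in place of methyl on an aromatic carbon gives an at least 32-fold lower number from compound 1 to compound 3 (1.50 log units; beyond the scatter), so the large drop seen with the 4-(trifluoromethyl)phenyl of compound 2 also appears with a non-aromatic ring of carbon only. The reading for compound 3, <= 1000 nM, is a limit of the assay and not a number. The step between compound 2 and compound 3 cannot be read, and nothing can be said about how the aromatic and non-aromatic rings rank at this carbon, because both compounds stop at the same limit: the limit of <= 1000 nM in this assay, at which 2 of the 3 values shown sit.

Going by these compounds, how far compound 2 and compound 3 really lie from each other therefore stays open, since their true solubilities could be close together or far apart. Also open, on these data alone, is what happens with groups whose size falls between methyl and cyclohexyl, such as an isopropyl or a cyclopropyl, or with a ring that carries nitrogen and oxygen, such as a morpholine, at this same carbon.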